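The compounds below may be only part of what the source reports. "The series", "measured", "known", "first", "only" and "open" are said of these compounds alone.

Compound 3, `C#CCN(C)Cc1ccc(NC(=O)CCC(=O)NO)cc1`, is the starting point. In a functional assay on PC-3 cells (Homo sapiens) for inhibition, read by MTT assay, with a stated time of 48 h (on this read-out higher numbers stand for weaker inhibition of growth and lower numbers for stronger inhibition of growth), compound 3 gives > 10000 nM, which is a limit of the assay rather than a measured number. Two other compounds share its core, with the amide-bearing arm attached to the ring at a different point: compound 1, `C#CCN(C)Cc1cccc(NC(=O)CCCC(=O)NO)c1`, and compound 2, `C#CCN(C)Cc1cccc(NC(=O)CCCCCC(=O)NO)c1`. In this assay compound 1 gives > 10000 nM, again a limit of the assay. In this assay compound 2 gives 4630 nM. For the measured compounds named here, the one measured step, an at least 2.1-fold lower number from compound 1 to compound 2 (0.33 log units; beyond the scatter), lengthens the chain between the amide and the hydroxycarbamoyl end, and the number falls.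

Compound 4, `C#CCN(C)Cc1ccc(NC(=O)CCCCCC(=O)NO)cc1`, applies a similar lengthening to compound 3: 3-(hydroxycarbamoyl)propyl in place of hydroxycarbamoyl on a saturated chain carbon, two bonds along the chain from a carbonyl carbon. Going by the values given here, that single step is the only guide, and because compound 1 and compound 3 both sit at the limit of > 10000 nM in this assay, at which 2 of the 3 values shown sit, its true size is known only as a lower bound. A drop of at least modest size in this assay is therefore expected for compound 4, an at least 2.0-fold lower number from compound 3 to compound 4 (0.30 log units; that floor lies within the scatter). Compound 4 is estimated at 5000 nM, within a range from 2000 nM to 15000 nM.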

Compound 4, concentration for 50% growth inhibition: > 10000 nM
Compound 4 ended at the assay's limit (the forecaster's own chance of this, stated with the estimate: 30%); middle value at least 2.0-fold (0.30 log units) from the limit.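

No size can be read for the step between compound 3 and compound 4, because both compounds end at a limit rather than a measured number: the limit of > 10000 nM in this assay, at which 3 of the 4 values shown sit.

The compounds shown leave open whether 3-(hydroxycarbamoyl)propyl in place of hydroxycarbamoyl changes the result at all in this assay.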